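The source may report more compounds than this note shows. Statements on the series, on what has been measured and on what is new or still open speak of the compounds shown alone.

Measured so far in a functional assay on U-373MG ATCC cells for cytotoxicity against U373 MG (Homo sapiens), read by colorimetric assay and MTT assay; on this read-out higher numbers stand for weaker inhibition and lower numbers for stronger inhibition:

Compound 1 `COc1cccc2cc(-c3ccccc3)c(O)nc12`: 10000 nM
Compound 2 `COc1ccc2cc(-c3ccccc3)c(O)nc2c1`: 10000 nM

On these numbers, compound 2 stands level with compound 1, and the two values lie within the usual scatter of repeated measurements. Among the measured compounds shown here, that pair is the whole of the evidence so far, and no measured step between closely matched compounds shows how this read-out responds to a single structural change.

The next compound to be tested is compound 3 `COc1cc(OC)c2cc(-c3ccccc3)c(O)nc2c1`. It is derived from compound 2 by one change, (methoxy in place of hydrogen on an aromatic carbon). The methoxy group enters on an aromatic carbon of the six-membered aromatic ring of carbon only, ortho to a fused ring and meta to a methoxy group.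

For the measured compounds named here, the only guide is that compound 1 gives 10000 nM and compound 2 gives 10000 nM, so no size or direction of step can be drawn from the data. In this assay, the expected change is no change at the digits printed from compound 2 to compound 3 (within the scatter), which means no step beyond the scatter in either direction. For compound 3, the estimated value is 10000 nM, with an expected range from 4000 nM to 25000 nM.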

Compound 3, half-maximal inhibitory concentration: 10000 nM
Compound 3: the middle estimate sits on the measured number at the digits printed, within the range that was stated.
By their numbers in this assay, from the lowest: compounds 1, 2 and 3 (each within the scatter of the next).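

In this assay, among the compounds shown here, methoxy in place of hydrogen on an aromatic carbon gives no change at the digits printed from compound 2 to compound 3 (within the scatter), the first single-place step that can be read in this set. At this position, ortho to a fused ring and meta to a methoxy group, adding this group to compound 2 therefore does not move the read-out beyond the scatter. No measurement shown here bears on why the value holds steady.

The compounds shown leave open whether another group at this position, such as an amine, a carboxylic acid or a longer chain, would produce a step beyond the scatter. They also leave open whether a change elsewhere on the shared core would shift the read-out at all, since no step shown here goes beyond the scatter in either direction.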